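The source may report more compounds than this note shows. Statements on the series, on what has been measured and on what is new or still open speak of the compounds shown alone.

Measured so far:
compound 1 `COc1cc(-c2cc(/C=C/C(=O)c3ccc(Cl)c(Cl)c3)[nH]n2)cc(OC)c1OC` with 50% 
compound 2 `COc1ccc(C(=O)/C=C/c2cc(-c3cc(OC)c(OC)c(OC)c3)n[nH]2)cc1OC` with -80% 

Compound 2 stands lowest of the two numbers in a functional assay on SNB-19 cells (Homo sapiens) for cytotoxicity, read by sulforhodamine B assay, with a stated time of 48 h, tested at 10 uM; on this read-out higher numbers stand for a weaker effect at the one concentration tested and lower numbers for a stronger effect; the nearest is compound 1, and the step of a number 130 percentage points lower from compound 1 to compound 2 (beyond the scatter) is large and beyond the scatter. Compound 3 `COc1ccc(C(=O)/C=C/c2cc(-c3cc(OC)c(OC)c(OC)c3)n[nH]2)cc1` is not yet measured. It differs from compound 2 in one place: hydrogen in place of methoxy on an aromatic carbon. Among the compounds with values here, the single measured step bears on it only loosely, as it also alters the aryl group on the carbonyl carbon, yet it exchanges one aryl for another rather than removing a methoxy. That step was large, which shows that this position responds strongly to change. The loss of one methoxy is a smaller change than the whole exchange, so a step in this assay toward a higher number, of moderate size, is expected, a number 40 percentage points higher from compound 2 to compound 3 (beyond the scatter). Compound 3 is therefore estimated at -40%, within -90% to 30%.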

Compound 3, a percentage reported as activity, at one concentration (the size of the read-out at that concentration, not a potency): -85%
Compound 3: the middle estimate sits 45 percentage points above what was measured, and the stated range covers the measured number.
By their numbers in this assay, from the lowest: compounds 3 and 2 (each within the scatter of the next); then compound 1.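

In this assay the second methoxy of the 3,4-dimethoxyphenyl group turns out not to be needed, since the step to 4-methoxyphenyl is a number 5 percentage points lower from compound 2 to compound 3 (within the scatter) and the two compounds cannot be told apart. One methoxy on this ring is enough for the large distance from the 3,4-dichlorophenyl compound, with a number 135 percentage points lower from compound 1 to compound 3 (beyond the scatter). Nothing in the available data accounts for this result.

Open, from the compounds shown here alone, is whether the remaining methoxy is itself needed, which an unsubstituted phenyl, or a hydroxyl or an amine on that carbon, would test. Also open, going by these compounds, are whether a longer chain such as ethoxy would serve there, and whether the weaker reading of compound 1 belongs to its chlorine atoms or simply to the absence of any methoxy.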